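A few compounds are considered here, and "the series" means these few. Any claim that something is new, unique, unknown or untested is made for them only; others in the source may bear on it.

Three members of the series have been run in a functional assay on PC-12 cells (Rattus norvegicus) for cytotoxicity, read by MTT assay, with stated times of 2 h and 24 h, tested at 10 uM; a lower number here means a weaker effect, a higher number a stronger effect of the compound at the concentration tested. Compound 1 `Oc1cc(C(F)(F)F)ccc1-c1nc(-c2ccccc2O)n(-c2ccc(Br)cc2)n1` gives 100%. Compound 2 `Oc1cc(C(F)(F)F)ccc1-c1nc(-c2ccccc2O)n(-c2ccc(C(F)(F)F)cc2)n1` gives 102%, and compound 3 `COc1cccc(-n2nc(-c3ccc(C(F)(F)F)cc3O)nc2-c2ccccc2O)c1` gives 106%, the highest of the three numbers, though its gaps to compound 2 and to compound 1 both lie within the scatter. The two changes of the group on the aromatic nitrogen so far were flat, a number 6 percentage points higher from compound 1 to compound 3 (within the scatter) and a number 4 percentage points higher from compound 2 to compound 3 (within the scatter), as was a number 2 percentage points higher from compound 1 to compound 2 (within the scatter) on the other ring. Compound 4 `Cc1cc(C)cc(-n2nc(-c3ccc(C(F)(F)F)cc3O)nc2-c2ccccc2O)c1` is the next point, with 3,5-dimethylphenyl in place of 3-methoxyphenyl on an aromatic nitrogen. Because a number 6 percentage points higher from compound 1 to compound 3 (within the scatter) and a number 4 percentage points higher from compound 2 to compound 3 (within the scatter) both stayed within the scatter, no step beyond the scatter is expected in this assay, and the expected step is a number 2 percentage points lower from compound 3 to compound 4 (within the scatter). Compound 4 is estimated at 104%, with a range from 94% to 114%.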

Compound 4, a percentage reported as activity, at one concentration (the size of the read-out at that concentration, not a potency): 105%
Compound 4: middle estimate off by 1 percentage points, on the low side; the measured number falls inside the stated range.
By their numbers in this assay, from the lowest: compounds 1, 2, 4 and 3 (each within the scatter of the next).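

Replacing 3-methoxyphenyl with 3,5-dimethylphenyl on the aromatic nitrogen removes the oxygen and the hydrogen-bond acceptor of the leaving group, and in this assay this gives a number 1 percentage points lower from compound 3 to compound 4 (within the scatter). The same group gives a number 3 percentage points higher from compound 2 to compound 4 (within the scatter) and a number 5 percentage points higher from compound 1 to compound 4 (within the scatter), so an aryl group carrying carbon substituents only reads like the other three at this position. Nothing available accounts for this flatness.

Still open, on these data alone, is whether an amine or a carboxylic acid on this aryl ring, or a longer alkyl chain in its place, would give a step beyond the scatter.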